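The source may hold more compounds than are shown below. What is called first, only, known or untested is meant among the compounds shown, and "the series" means these compounds.

Measured compounds:
- compound 1 `CN(C(=O)C(C)(C)C)c1ccc2[nH]c(-c3n[nH]c4ccccc34)cc2n1`: 22200 nM
- compound 2 `COc1ccc(C(=O)N(C)c2ccc3[nH]c(-c4n[nH]c5ccccc45)cc3n2)cc1`: 23700 nM
- compound 3 `CN(c1ccc2[nH]c(-c3n[nH]c4ccccc34)cc2n1)S(=O)(=O)c1ccccc1`: 12000 nM

All three were tested in a functional assay on SMMC-7721 cells (Homo sapiens) for antiproliferative activity, read by MTT assay, with a stated time of 72 h; on this read-out higher numbers stand for weaker inhibition and lower numbers for stronger inhibition. Compound 3 gives the lowest of the three numbers, but the step of a 1.9-fold lower number from compound 1 to compound 3 (0.27 log units; within the scatter) and the step of a 2.0-fold lower number from compound 2 to compound 3 (0.30 log units; within the scatter) both stay within the scatter, so compound 3 cannot be set apart from the other two.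

Compound 4 `Cc1ccc(S(=O)(=O)N(C)c2ccc3[nH]c(-c4n[nH]c5ccccc45)cc3n2)cc1` differs from compound 3 by methyl in place of hydrogen on an aromatic carbon. Within the data shown here, none of the measured steps touches this phenyl ring: a 1.1-fold higher number from compound 1 to compound 2 (0.03 log units; within the scatter) swaps the group on a carbonyl carbon, and the two steps into compound 3 exchange the whole group on the ring nitrogen. All three steps stay within the scatter, so the shared core seems to tolerate changes at this end without large shifts, and a single methyl added to the phenyl ring is a smaller change than any of them.

The step of no change at the digits printed from compound 3 to compound 4 (within the scatter) is therefore expected to lie within the scatter. Compound 4 is estimated at 12000 nM, with a range from 5500 nM to 26000 nM.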

Compound 4, half-maximal inhibitory concentration: 16300 nM
Estimate against measurement, compound 4: 1.4-fold (0.13 log units) below; measured number inside the range.
By their numbers in this assay, from the lowest: compounds 3, 4, 1 and 2 (each within the scatter of the next).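

In this assay, among these compounds, this is the first change made on the six-membered aromatic ring itself, para to a large group, and not an exchange of the whole group on the nitrogen: methyl in place of hydrogen gives a 1.4-fold higher number from compound 3 to compound 4 (0.13 log units; within the scatter) and stays within the scatter. The (4-methylphenyl)sulfonyl group also cannot be told apart from the two carbonyl groups, with a 1.5-fold lower number from compound 2 to compound 4 (0.16 log units; within the scatter) and with a 1.4-fold lower number from compound 1 to compound 4 (0.13 log units; within the scatter) as well. No measurement is available that would explain these small steps.

As far as these compounds go, whether an amine, a carboxylic acid or a longer chain at this same place would give a step beyond the scatter remains open. From the compounds shown here alone, it is also open whether a methyl on the ring of compound 2 would give a similar small step.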